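Acetyl Removal at a Ring Oxygen in Three Measured Analogues

A few compounds are considered here, and "the series" means these few. Any claim that something is new, unique, unknown or untested is made for them only; others in the source may bear on it.

The measured compounds are:
compound 1 `CC(=O)Oc1cc2oc(-c3ccccc3)cc(=O)c2c(O)c1OC(C)=O`, which in a functional assay on KB cells (Homo sapiens) for inhibition, with a stated time of 72 h (on this read-out higher numbers stand for weaker inhibition and lower numbers for stronger inhibition), gives 12700 nM;
compound 2 `CC(=O)Oc1cc2oc(-c3ccccc3)cc(=O)c2c(OC(C)=O)c1OC(C)=O`, which in this assay gives 14500 nM;
compound 3 `CC(=O)Oc1cc2oc(-c3ccccc3)cc(=O)c2c(O)c1OCc1ccccc1`, which in this assay gives 16300 nM.

Compound 4 `O=c1cc(-c2ccccc2)oc2cc(O)c(OCc3ccccc3)c(O)c12` has not yet been measured. It differs from compound 3 by hydrogen in place of acetyl on an oxygen on an aromatic ring. The same change, at the same kind of place, separates compound 2 from compound 1, namely (hydrogen in place of acetyl on an oxygen on an aromatic ring), and there it made a 1.1-fold lower number from compound 2 to compound 1 (0.06 log units; within the scatter). How the core of compound 3 differs from that of compound 2 is not broken down here. Going by the values given here, since the one precedent lies within the scatter, the step from compound 3 to compound 4 is expected to be similar in size, a 1.1-fold lower number from compound 3 to compound 4 (0.05 log units; within the scatter), resting on a 1.1-fold lower number from compound 2 to compound 1 (0.06 log units; within the scatter). Compound 4 is therefore estimated at 14500 nM, with a likely range from 6000 nM to 36000 nM.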

Compound 4, half-maximal inhibitory concentration: 4300 nM
The estimate for compound 4 lay 3.4-fold (0.53 log units) above the measured number, outside the stated range (below it).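

In this assay, putting hydrogen in place of acetyl on an oxygen on an aromatic ring gave a 3.8-fold lower number from compound 3 to compound 4 (0.58 log units; beyond the scatter), and this step does not match the one seen earlier on the other core: the same change on two cores in this assay, a 1.1-fold lower number (0.06 log units; within the scatter) from compound 2 to compound 1 and a 3.8-fold lower number (0.58 log units; beyond the scatter) from compound 3 to compound 4, 3.3-fold (0.52 log units) apart, beyond the scatter of two such steps. Going by these compounds alone, the size of this change therefore did not carry from one core to the other, and a small step on one core was no guide to the step on the other. With a single pair on each core, this does not show which difference between the cores sets the gap, nor how the change behaves on any further core.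

Going by these compounds, it remains open whether a step of either size would appear with a methyl group or a longer chain in place of benzyl. The same question stands for a core carrying an amine or a carboxylic acid.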